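The source may report more compounds than this note shows. Statements on the series, on what has been measured and on what is new or still open speak of the compounds shown alone.

Measured so far in an assay for inhibition of histone-lysine N-methyltransferase, H3 lysine-79 specific (Homo sapiens), read by scintillation counting, with stated times of 15 min and 60 min, in the presence of a further agent that is not named here; on this read-out lower numbers stand for stronger inhibition and higher numbers for weaker inhibition:
compound 1, `Cc1cccc(-c2nnc3sc(/C=C/c4ccco4)nn23)c1`, gives 9410 nM
compound 2, `C(=C/c1nn2c(-c3ccccc3)nnc2s1)\c1ccco1`, gives 7010 nM

For the measured compounds named here, compound 2 stands at the lower of the two numbers recorded, but its only neighbour is compound 1, and the step of a 1.3-fold lower number from compound 1 to compound 2 (0.13 log units; within the scatter) lies within the scatter of the assay, so the two compounds cannot be set in order. The next compound, compound 3 `CN(C)c1ccc(-c2nnc3sc(/C=C/c4ccco4)nn23)cc1`, differs from compound 2 by dimethylamino in place of hydrogen on an aromatic carbon. Going by the values given here, only one measured step bears on this change at all: the step from compound 1 to compound 2 also concerns a substituent on the six-membered aromatic ring of carbon only, a methyl giving way to hydrogen, and it produced no movement beyond the scatter. Among the compounds with values here, no measured compound carries a dimethylamino group, nor any group that enters rather than leaves, so the record gives no direction for the new substituent. In the account's view the step of a 1.2-fold lower number from compound 2 to compound 3 (0.07 log units; within the scatter) is therefore expected to stay within the scatter. Compound 3 is accordingly estimated at 6000 nM, within a range from 2000 nM to 20000 nM.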

Compound 3, half-maximal inhibitory concentration: 20900 nM
The estimate for compound 3 lay 3.5-fold (0.54 log units) below the measured number; measured number outside the range, above it.
By their numbers in this assay, from the lowest: compounds 2 and 1 (each within the scatter of the next); then compound 3.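

In this assay, for the compounds shown here, dimethylamino in place of hydrogen on an aromatic carbon, para to a large group, gives a 3.0-fold higher number from compound 2 to compound 3 (0.47 log units; beyond the scatter), the first step on this six-membered ring that lies beyond the scatter, though it remains modest. The earlier step, a 1.3-fold lower number from compound 1 to compound 2 (0.13 log units; within the scatter), showed only that losing a methyl left the number within the scatter; the new step shows that this ring can tolerate a change poorly, since an entering group at this place moves the number towards weaker inhibition. No measurement given here accounts for this shift.

The compounds shown leave open whether the shift belongs to dimethylamino in particular or would follow any group at this place, since only this one substituent stands there. A plain amino group or a methoxy group at the same place would help separate these possibilities, and a fluorine or a carboxylic acid there would show whether any substituent at this place can hold the number near that of compound 2 or even lower it.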